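From compound 3 to compound 4: a methoxy shift

The source may report more compounds than this note shows. Statements on the series, on what has been measured and on what is new or still open speak of the compounds shown alone.

In a toxicity assay on L3.6pl cells (Homo sapiens) for inhibition, read by ATP content, with a stated time of 72 h (on this read-out lower numbers stand for stronger inhibition and higher numbers for weaker inhibition), compound 1 (`COc1ccc(C(=O)Nc2ccc(N3CCCN(c4ncccn4)CC3)cc2C(=O)O)cc1`) gives > 30000 nM, which is a limit of the assay and not a number. Compound 2 (`COc1ccc(C(=O)Nc2ccc(N3CCN(c4ccccc4Cl)CC3)cc2C(=O)O)cc1`) gives 125000 nM, and compound 3 (`COc1ccc(C(=O)Nc2ccc(N3CCN(c4cc(Cl)ccc4C)CC3)cc2C(=O)O)cc1`) gives 16800 nM, the lower of the two numbers. Compound 4 (`COc1ccccc1C(=O)Nc1ccc(N2CCN(c3cc(Cl)ccc3C)CC2)cc1C(=O)O`) carries 2-methoxyphenyl in place of 4-methoxyphenyl on a carbonyl carbon. Among the compounds with values here, the one measured step, a 7.4-fold lower number from compound 2 to compound 3 (0.87 log units; beyond the scatter), is modest and lies on an amine nitrogen in a ring, so it gives no size for a change on a carbonyl carbon. From the compounds shown here alone, no step beyond the scatter is therefore expected in this assay, and the direction remains open. The expected step is a 1.2-fold higher number from compound 3 to compound 4 (0.08 log units; within the scatter). For compound 4 the estimate is 20000 nM, with an expected range of 6000 nM to 65000 nM.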

Compound 4, half-maximal inhibitory concentration: 29100 nM
The estimate for compound 4 lay 1.5-fold (0.16 log units) below the measured number, within the range that was stated.
By their numbers in this assay, from the lowest: compounds 3 and 4 (each within the scatter of the next); then compound 2.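

In this assay, 2-methoxyphenyl in place of 4-methoxyphenyl on a carbonyl carbon gives a 1.7-fold higher number from compound 3 to compound 4 (0.24 log units; within the scatter), so moving the methoxy group here produces no readable change. Within the data shown here, the earlier step, a 7.4-fold lower number from compound 2 to compound 3 (0.87 log units; beyond the scatter), lay on an amine nitrogen in a ring, and this result gives the carbonyl side its only reading so far. Compound 1 gives a limit and not a number: the limit of > 30000 nM in this assay, at which 1 of the 4 values shown sits.

From the compounds shown here alone, whether a nitrile or a longer alkoxy chain in place of the methoxy group shifts the number stays open. Also open, going by these compounds, is whether the methoxy shift reads the same with 2-chlorophenyl on the amine nitrogen.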